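From 2-fluorophenyl to 2-methylphenyl in the series

This account rests on a few compounds, and the source may have more. Where it says the series, first, only, none or still open, it means among the compounds named here.

In a toxicity assay on MT4 cells (Homo sapiens) for cytotoxicity, read by MTT assay (on this read-out lower numbers stand for higher toxicity in this test and higher numbers for lower toxicity in this test), compound 2 (`Cc1cc(-c2ccccc2F)cc(C)c1Oc1cc(N)nc(Nc2ccc(C#N)cc2)n1`) gives 29300 nM and compound 3 (`Cc1cc(-c2cccc(Cl)c2)cc(C)c1Oc1cc(N)nc(Nc2ccc(C#N)cc2)n1`) gives 22300 nM with the two numbers within the scatter of each other. Compound 1 (`COc1cc(Oc2cc(N)nc(Nc3ccc(C#N)cc3)n2)ccc1-c1ccc(C#N)cc1`) gives 12900 nM in this assay and this number lies lower than that of compound 2 by more than the scatter.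

Compound 4 (`Cc1ccccc1-c1cc(C)c(Oc2cc(N)nc(Nc3ccc(C#N)cc3)n2)c(C)c1`) differs from compound 2 in one place: methyl in place of fluoro on an aromatic carbon (methyl in place of fluoro on an aromatic carbon, ortho to a large group).

For the measured compounds named here, the only measured step at this group, a 1.3-fold lower number from compound 2 to compound 3 (0.12 log units; within the scatter) (3-chlorophenyl in place of 2-fluorophenyl), stays within the scatter. Going by the values given here, compound 1 offers no single-place step to compound 2. Among the compounds with values here, no measured compound carries the 2-methylphenyl group, so the data hold no direct test of it.

No step beyond the scatter is therefore expected in this assay for this change. Expected is a 1.2-fold lower number from compound 2 to compound 4 (0.09 log units; within the scatter) and so no shift beyond the scatter. For compound 4 the estimated value is 24000 nM with an expected range from 10000 nM to 50000 nM as a working figure.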

Compound 4, half-maximal cytotoxic concentration: 25600 nM
Estimate against measurement, compound 4: 1.1-fold (0.03 log units) below; low and high end bracket the measured number.
By their numbers in this assay, from the lowest: compounds 1, 3, 4 and 2 (each within the scatter of the next, the first and the last beyond it).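

In this assay, the 2-methylphenyl group now has a direct reading: methyl in place of fluoro on an aromatic carbon, ortho to a large group, gives a 1.1-fold lower number from compound 2 to compound 4 (0.06 log units; within the scatter). Against the 3-chlorophenyl group, the change of aryl group gives a 1.1-fold higher number from compound 3 to compound 4 (0.06 log units; within the scatter), so the 2-fluorophenyl, 3-chlorophenyl and 2-methylphenyl groups on the shared core all lie within the scatter of one another. No supporting measurement is at hand that would explain this result.

Going by these compounds, it remains open whether an amine, a carboxylic acid or a longer chain in place of the fluoro or methyl group would move the number beyond the scatter. For the compounds shown here, compound 1 still has no single-place step to any other compound, so its lower number cannot be assigned to any one group.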